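The source may report more compounds than this note shows. Statements on the series, on what has been measured and on what is new or still open speak of the compounds shown alone.

Three compounds share one core and differ only in the group attached to its carbonyl carbon. Compound 1 `COc1cc2c(cc1OC)C(CC(=O)O)CC2` gives 23.9% in a functional assay on the whole organism (strain Wistar) for inhibition, with Rattus norvegicus as the target, read by paw edema, with stated times of 60 min and 4 h, at a dose of 100 mg/kg by the oral route; on this read-out lower numbers stand for less inhibition and higher numbers for more inhibition at the one dose given (going by the name of the read-out). Compound 2 `CCCNC(=O)CC1CCc2cc(OC)c(OC)cc21` gives 26.6% in the same test, and compound 3 `COc1cc2c(cc1OC)C(CC(=O)NC(C)(C)C)CC2` gives 32.8%. The number for compound 3 is the highest of the three, yet both distances to it lie within the scatter: a number 8.9 percentage points higher from compound 1 to compound 3 (within the scatter) and a number 6.2 percentage points higher from compound 2 to compound 3 (within the scatter). Compound 4 `CCCCCCNC(=O)CC1CCc2cc(OC)c(OC)cc21` differs from compound 3 at the amide-type nitrogen: hexyl in place of tert-butyl on an amide-type nitrogen. For the measured compounds named here, the one measured step at this same place, a number 6.2 percentage points higher from compound 2 to compound 3 (within the scatter), was within the scatter, so a change of the chain on this nitrogen is expected to shift the read-out little: a number 2.8 percentage points lower from compound 3 to compound 4 (within the scatter). Compound 4 is therefore estimated at 30%, with a range from 18% to 42%.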

Compound 4, a percentage reported as inhibition, in the whole organism at one dose (the size of the read-out at that dose, not a potency): 42.1%
Compound 4: the middle estimate sits 12.1 percentage points below what was measured; the measured number lies above the stated range.
By their numbers in this assay, from the lowest: compounds 1, 2, 3 and 4 (each within the scatter of the next, the first and the last beyond it).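

With hexyl on the amide-type nitrogen, the series shows its first steps beyond the scatter: a number 15.5 percentage points higher from compound 2 to compound 4 (beyond the scatter) against the propyl amide and a number 18.2 percentage points higher from compound 1 to compound 4 (beyond the scatter) against the acid. For the compounds shown here, the chain on this nitrogen can therefore move the read-out, which the earlier steps did not show. Against tert-butyl alone the change does not stand out, with a number 9.3 percentage points higher from compound 3 to compound 4 (within the scatter) as the only difference between them.

Going by these compounds, whether a longer chain such as octyl, or a hexyl chain ending in an amine, would give a higher number remains open. No evidence at hand explains the higher number for hexyl.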